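Taking one methyl off the linker carbon of compound 2

The compounds below may be only part of what the source reports. "The series", "measured", "known", "first", "only" and "open" are said of these compounds alone.

Compound 1 `CCCN(CC1CC1)c1cc(Cc2c(OC)cc(OC)cc2OC)nc(C)n1` gives 26 nM in an assay on isolated protein for binding affinity to corticotropin-releasing factor receptor 1 (Homo sapiens); a lower number here means a stronger inhibitor, a higher number a weaker inhibitor.
Compound 2 `CCCN(CC1CC1)c1cc(C(C)(C)c2c(OC)cc(OC)cc2OC)nc(C)n1` reaches only a limit of this assay, > 10000 nM.
Compound 3 `C=C(c1cc(N(CCC)CC2CC2)nc(C)n1)c1c(OC)cc(OC)cc1OC` gives 560 nM in this assay.

Compound 2 thus stands at the floor of what this assay reports, (the limit of > 10000 nM in this assay, at which 1 of the 3 values shown sits), and no number is known for it. Compound 1 and compound 3, each with a different linker carbon, sit at numbers rather than at the limit. Compound 4 `CCCN(CC1CC1)c1cc(C(C)c2c(OC)cc(OC)cc2OC)nc(C)n1` differs from compound 2 by hydrogen in place of methyl on a saturated chain carbon bound to two aromatic carbons and a saturated chain carbon. Among the compounds with values here, no measured step covers this change. Compound 4 is expected to show a step toward lower numbers, beyond the scatter, an at least 33-fold lower number from compound 2 to compound 4 (1.52 log units; beyond the scatter). Compound 4 is therefore estimated at 300 nM, within 50 nM to 3000 nM.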

Compound 4, inhibition constant: 480 nM
Estimate against measurement, compound 4: 1.6-fold (0.20 log units) below; the range from low to high includes it.
By their numbers in this assay, from the lowest: compound 1; then compounds 4 and 3 (each within the scatter of the next). At a limit, above all of these: compound 2.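

In this assay, this result separates the effects of the two methyls on the linker carbon: taking one away gives an at least 20-fold lower number from compound 2 to compound 4 (1.31 log units; beyond the scatter), while adding a single methyl to the unbranched linker of compound 1 already gives an 18-fold higher number from compound 1 to compound 4 (1.27 log units; beyond the scatter). One methyl is therefore enough for a large loss, and the second brings a further one of unknown size. Compound 2 stands at a limit, not a number: the limit of > 10000 nM in this assay, at which 1 of the 4 values shown sits.

On these data alone, what a hydroxyl, a fluorine or an ethyl on this linker carbon would give in this assay stays open.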